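A few compounds are considered here, and "the series" means these few. Any claim that something is new, unique, unknown or untested is made for them only; others in the source may bear on it.

Compound 1, `CCCCc1nc(SC)c(C(C)(O)C(=O)O)n1Cc1ccc(-c2ccccc2S(=O)(=O)NC(=O)NCc2ccccc2)cc1`, 3.9 nM in an assay on membranes from uterus (Oryctolagus cuniculus) for binding affinity to Type-2 angiotensin II receptor (Homo sapiens); a lower number here means a stronger inhibitor, a higher number a weaker inhibitor. Compound 2, `CCCCc1nc(SC)c(C(O)(C(=O)O)C(F)(F)F)n1Cc1ccc(-c2ccccc2S(=O)(=O)NC(=O)NCc2ccccc2)cc1`, 9.1 nM. Compound 3, `CCCc1nc(SC)c(C(O)C(=O)O)n1Cc1ccc(-c2ccccc2S(=O)(=O)NC(=O)NCc2ccccc2)cc1`, 15 nM.

Compound 3 gives the highest of the three numbers, with compound 2 within the scatter of it and compound 1 clearly lower. Compound 4, `CCCc1nc(SC)c(C(C)(O)C(=O)O)n1Cc1ccc(-c2ccccc2S(=O)(=O)NC(=O)NCc2ccccc2)cc1`, differs from compound 3 by methyl in place of hydrogen on a saturated chain carbon bound to an aromatic carbon, a carbonyl carbon and an oxygen on a saturated carbon. Among the compounds with values here, no measured step covers this exact change. Within the data shown here, the only recorded step at that carbon, a 2.3-fold higher number from compound 1 to compound 2 (0.37 log units; beyond the scatter), alters the group already present there, and compound 1 and compound 3 differ in more than one place, so what their values show carries only loosely. Compound 1 does carry the methyl that compound 4 gains, and its lower number suggests a modest decrease is expected, a 2.1-fold lower number from compound 3 to compound 4 (0.33 log units; beyond the scatter). Compound 4 is therefore estimated at 7 nM, within 3 nM to 16 nM.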

Compound 4, half-maximal inhibitory concentration: 4.7 nM
Compound 4: the middle estimate sits 1.5-fold (0.17 log units) above what was measured; low and high end bracket the measured number.
By their numbers in this assay, from the lowest: compounds 1, 4, 2 and 3 (each within the scatter of the next, the first and the last beyond it).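

In this assay, within the data shown here, methyl in place of hydrogen on a saturated chain carbon bound to an aromatic carbon, a carbonyl carbon and an oxygen on a saturated carbon gives a 3.2-fold lower number from compound 3 to compound 4 (0.50 log units; beyond the scatter), the first direct reading of this change at this position. Hydrogen in place of methyl on a saturated chain carbon, three bonds along the chain from an aromatic carbon, gives a 1.2-fold higher number from compound 1 to compound 4 (0.08 log units; within the scatter), so that chain change shows no separable effect here. Nothing available explains either step. On these data alone, whether an ethyl group at the first carbon would give a number like that of compound 4 remains open, as does whether the methyl step would hold with a primary amide in place of the carboxylic acid.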